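O-Alkylation of a hydroxamate at the 2-oxoglutarate receptor

A few compounds are considered here, and "the series" means these few. Any claim that something is new, unique, unknown or untested is made for them only; others in the source may bear on it.

Measured compounds:
compound 1 `CCCCCCCNC(=O)[C@H]1OC(n2cnc3c(N)ncnc32)[C@H](O)[C@@H]1O` — 20 nM
compound 2 `Nc1ncnc2c1ncn2C1O[C@H](C(=O)NO)[C@@H](O)[C@H]1O` — 41 nM

In an assay on cell membranes for binding affinity to 2-oxoglutarate receptor 1 (Rattus norvegicus), read by radioligand binding (a lower number here means a stronger inhibitor, a higher number a weaker inhibitor), compound 1 gives 20 nM, and compound 2 gives 41 nM. Compound 2 therefore holds the higher of the two numbers, its nearest neighbour being compound 1 at a 2.1-fold higher number from compound 1 to compound 2 (0.31 log units; beyond the scatter).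

Compound 3 `CCONC(=O)[C@H]1OC(n2cnc3c(N)ncnc32)[C@H](O)[C@@H]1O` is not yet measured. It differs from compound 2 by ethyl in place of hydrogen on an oxygen. Going by the values given here, the only measured step that touches this part of the molecule is the exchange of the substituent on the amide-type nitrogen, a 2.1-fold higher number from compound 1 to compound 2 (0.31 log units; beyond the scatter), which was modest. Among the compounds with values here, no measured pair shows an alkyl group entering on the hydroxy oxygen itself, so the direction of the step is uncertain, and only a small shift is expected in this assay.

Compound 3 is estimated at 40 nM, with a range from 15 nM to 120 nM, which corresponds to an expected step of a 1.0-fold lower number from compound 2 to compound 3 (0.01 log units; within the scatter).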

Compound 3, inhibition constant: 67 nM
The estimate for compound 3 lay 1.7-fold (0.22 log units) below the measured number; low and high end bracket the measured number.
By their numbers in this assay, from the lowest: compound 1; then compounds 2 and 3 (each within the scatter of the next).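

Putting ethyl on the oxygen whose other neighbour is the amide-type nitrogen gives a 1.6-fold higher number from compound 2 to compound 3 (0.21 log units; within the scatter) in this assay, so this oxygen accepts an ethyl group with no shift that can be told from the scatter of repeated measurements. Ethoxy in place of heptyl on the amide-type nitrogen gives a 3.4-fold higher number from compound 1 to compound 3 (0.53 log units; beyond the scatter), a modest step that, unlike the first, lies beyond the scatter. Nothing available accounts for the size of either step.

The compounds shown leave open whether a longer chain on this oxygen, such as butyl or heptyl, would stay within the scatter of the ethoxy compound 3. They also do not tell how a benzyl group on the same oxygen, or a methoxy group in place of ethoxy, would read in this assay.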